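Working notes: compound 3 expected from compound 2

The source may hold more compounds than are shown below. What is called first, only, known or untested is meant among the compounds shown, and "the series" means these compounds.

Measured so far:
compound 1 `O=C(CSc1nnnn1-c1ccccc1)N/N=c1/scc(-c2ccc(F)cc2)n1-c1ccccc1` — 43.7%
compound 2 `Cn1nnnc1SCC(=O)N/N=c1/scc(-c2ccc(C#N)cc2)n1-c1ccccc1` — 35.6%

In a functional assay on C6 cells (Rattus norvegicus) for cytotoxicity, read by MTT assay, with a stated time of 24 h, tested at 50 ug/mL (a lower number here means a stronger effect, a higher number a weaker effect of the compound at the concentration tested), compound 2 stands at the lowest of the two numbers, with compound 1 a number higher by an amount within the scatter, so no order between the two is claimed. Compound 3 `N#Cc1ccc(-c2cs/c(=N/NC(=O)CSc3nnnn3-c3ccccc3)n2-c2ccccc2)cc1` is not yet measured. It differs from compound 2 by phenyl in place of methyl on an aromatic nitrogen. Going by the values given here, no single-change step between measured compounds exists here. As the two measured values lie within the scatter of each other, the step expected from compound 2 to compound 3 is a number 4.4 percentage points higher from compound 2 to compound 3 (within the scatter), none beyond the scatter. Compound 3 is estimated at 40% in this assay, in a range from 25% to 55%.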

Compound 3, a percentage reported as activity, at one concentration (the size of the read-out at that concentration, not a potency): 61.1%
The estimate for compound 3 lay 21.1 percentage points below the measured number, outside the stated range (above it).
By their numbers in this assay, from the lowest: compounds 2 and 1 (each within the scatter of the next); then compound 3.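

In this assay, phenyl in place of methyl on the aromatic nitrogen gives a number 25.5 percentage points higher from compound 2 to compound 3 (beyond the scatter), so the effect at the tested concentration responds to the group at this position. With 1-phenyl-1H-tetrazol-5-yl held fixed, cyano in place of fluoro on an aromatic carbon gives a number 17.4 percentage points higher from compound 1 to compound 3 (beyond the scatter), so a change elsewhere on the molecule also shifts the number. Nothing available explains either step.

From the compounds shown here alone, it remains open where an ethyl or benzyl group on that nitrogen would fall relative to methyl and phenyl. Going by these compounds, whether the cyano to fluoro step has the same size with methyl on that nitrogen also remains open.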